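The compounds below may be only part of what the source reports. "The series", "measured", "known", "first", "only" and "open" are said of these compounds alone.

The measured compounds are:
Compound 1, `CCCCC/C=C\C/C=C\CCCCCCCc1cc(=O)c2c(O)cc(O)cc2o1`, giving 6790 nM in a functional assay on MDA-MB-231 cells (Homo sapiens) for antiproliferative activity, read by MTT assay; on this read-out lower numbers stand for stronger inhibition and higher numbers for weaker inhibition.
Compound 2, `CCCCC/C=C\C/C=C\CCCCCCCc1cc(=O)c2c(O)cc(OCOC)cc2o1`, for which this assay reports only a limit, > 87000 nM.
Compound 3, `CCCC/C=C\CCCCCCCCCc1cc(=O)c2c(O)cc(O)cc2o1`, giving 6790 nM in this assay.

Compound 1 stands level with compound 3: no change at the digits printed from compound 1 to compound 3 (within the scatter), with oct-3-en-1-yl in place of deca-1,4-dien-1-yl on a saturated chain carbon, seven bonds along the chain from an aromatic carbon. The remaining value is the limit recorded for compound 2. That step is the large one: an at least 12-fold higher number from compound 1 to compound 2 (1.10 log units; beyond the scatter), with methoxymethyl in place of hydrogen on an oxygen on an aromatic ring, the value reaching (the limit of > 87000 nM in this assay, at which 1 of the 3 values shown sits).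

Compound 4, `CCCCC/C=C\C/C=C\CCCCCCCc1cc(=O)c2c(O)c(C)c(O)cc2o1`, differs from compound 1 by methyl in place of hydrogen on an aromatic carbon. Neither measured step touches this ring carbon. The chain step shows that the core tolerates change at a distance without moving the number, while the hydroxy-capping step, which cost so much, removes a hydroxy hydrogen that compound 4 keeps. Nothing measured therefore bears directly on a methyl at this site, and the expectation is a step within the scatter: a 1.0-fold higher number from compound 1 to compound 4 (0.01 log units; within the scatter). Compound 4 is accordingly estimated at 7000 nM in this assay, within 2500 nM to 20000 nM.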

Compound 4, half-maximal inhibitory concentration: 16100 nM
Compound 4: the middle estimate sits 2.3-fold (0.36 log units) below what was measured, and the stated range covers the measured number.
By their numbers in this assay, from the lowest: compounds 1 and 3 (each within the scatter of the next); then compound 4. At a limit, above all of these: compound 2.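

In this assay, methyl in place of hydrogen on this aromatic carbon, ortho to two hydroxy groups, gives a 2.4-fold higher number from compound 1 to compound 4 (0.37 log units; beyond the scatter) and so shows that the shared core responds to a change on the ring itself even when both hydroxy groups are kept, something the chain step from compound 1 to compound 3 could not show. The cost of this change is modest, and compound 4 still gives a measured number, whereas compound 2, with a hydroxy hydrogen replaced by methoxymethyl, is recorded only at the limit > 87000 nM in the same assay. The values shown offer no measured property that would explain why methyl on this carbon moves the number.

The compounds shown leave open whether the step belongs to methyl alone or to any group at this site, since an ethyl, a methoxy or a fluorine on the same carbon could move the number further, less or the other way. They also leave open whether methyl would give a similar step on the oct-3-en-1-yl chain of compound 3.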